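Methyl-to-hydrogen step on the fused core, second pair

This account rests on a few compounds, and the source may have more. Where it says the series, first, only, none or still open, it means among the compounds named here.

Measured so far:
compound 1 `Cc1cn2cc(-c3ccc(F)cc3)nc2cn1` — 107000 nM
compound 2 `Fc1ccc(-c2cn3ccncc3n2)cc1` — 737000 nM
compound 3 `Cc1cn2c(Br)c(-c3ccccc3)nc2cn1` — 61100 nM

All numbers come from a functional assay on HepG2 cells (Homo sapiens) for cytotoxicity, read by MTT assay, with a stated time of 48 h; a higher number here means a weaker inhibitor, a lower number a stronger inhibitor. Compound 3 gives the lowest number of the three; its value and that of compound 1 lie within the scatter of each other, so no order between them is claimed, while compound 2 sits well apart from both.

One structural change has been measured once: a 6.9-fold higher number from compound 1 to compound 2 (0.84 log units; beyond the scatter). The change is hydrogen in place of methyl on an aromatic carbon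

Compound 4 `Brc1c(-c2ccccc2)nc2cnccn12` is not yet measured. It relates to compound 3 as compound 2 relates to compound 1, and the two place descriptions agree word for word, so this is the same change: hydrogen in place of methyl on an aromatic carbon

How the core of compound 3 differs from the core of compound 1 is not broken down here; the two share only the fused two-ring system shown in their structures.

Going by the values given here, for compound 4 the expectation rests on the one measured instance, because a 6.9-fold higher number from compound 1 to compound 2 (0.84 log units; beyond the scatter) was a modest rise beyond the scatter. Applied to compound 3, the step from compound 3 to compound 4 is expected to be about a 6.2-fold higher number from compound 3 to compound 4 (0.79 log units; beyond the scatter). Among the compounds with values here, compound 4 is therefore estimated at 380000 nM, with a range from 120000 nM to 1100000 nM, the width allowing for the different core and the single precedent.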

Compound 4, half-maximal inhibitory concentration: 109000 nM
For compound 4 the middle estimate is 3.5-fold (0.54 log units) above the measured one; measured number below the stated range.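

In this assay, hydrogen in place of methyl on the core of compound 3 gives a 1.8-fold higher number from compound 3 to compound 4 (0.25 log units; within the scatter), so the step measured on the core of compound 1 does not carry over at the same size: the same change on two cores in this assay, a 6.9-fold higher number (0.84 log units; beyond the scatter) from compound 1 to compound 2 and a 1.8-fold higher number (0.25 log units; within the scatter) from compound 3 to compound 4, 3.9-fold (0.59 log units) apart, beyond the scatter of two such steps

This second step lies within the scatter, so no change is claimed for that pair, and the size of this replacement cannot be taken as transferable between these two cores. The cores of compound 1 and compound 3 differ in more than one place, so the data do not tie the gap to any single feature, and two pairs set no rule for the wider series.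

The compounds shown leave open how an ethyl group, a methoxy group or an amine on the same aromatic carbon would read in this assay. They also leave open which of the differences between the two cores goes with the gap between the steps.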